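The source may report more compounds than this note shows. Statements on the series, on what has been measured and on what is new or still open speak of the compounds shown alone.

Among the measured compounds shown here, compound 2 `CN1CCN(CCC(=O)O[C@@H]2C[C@@H]3CC[C@@]2(C)C3(C)C)CC1` stands at the highest of the two numbers measured so far in an ADME assay on HEK-293T cells (Homo sapiens) for cytotoxicity, read by MTT assay, with a stated time of 48 h (a lower number here means that less compound is tolerated, a higher number that more compound is tolerated), giving 282000 nM. For the measured compounds named here, its only neighbour is compound 1 `CC1(C)[C@H]2CC[C@]1(C)[C@H](OC(=O)CCCN1CCCCC1)C2`, which in this assay gives 74800 nM; between them the change was a 3.8-fold higher number from compound 1 to compound 2 (0.58 log units; beyond the scatter). Compound 3 `CC1(C)[C@H]2CC[C@]1(C)[C@H](OC(=O)CCN1CCCCCC1)C2` differs from compound 2 in one place: azepan-1-yl in place of 4-methylpiperazin-1-yl on a saturated chain carbon, two bonds along the chain from a carbonyl carbon. Going by the values given here, the single measured step that bears on this is the one from compound 1 to compound 2, in which piperidin-1-yl gave way to 4-methylpiperazin-1-yl and the number rose beyond the scatter; the present exchange runs in the opposite sense, bringing in azepan-1-yl, a ring more like that of compound 1. A modest step downward, beyond the scatter, is therefore expected. For compound 3 the estimate in this assay is 90000 nM, within 40000 nM to 200000 nM, the expected step being a 3.1-fold lower number from compound 2 to compound 3 (0.50 log units; beyond the scatter).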

Compound 3, half-maximal cytotoxic concentration: 183000 nM
Estimate against measurement, compound 3: 2.0-fold (0.31 log units) below, within the range that was stated.
By their numbers in this assay, from the lowest: compound 1; then compounds 3 and 2 (each within the scatter of the next).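

In this assay, azepan-1-yl in place of 4-methylpiperazin-1-yl at this saturated chain carbon gives a 1.5-fold lower number from compound 2 to compound 3 (0.19 log units; within the scatter), so the seven-membered ring with one hetero atom and the six-membered ring with two hetero atoms cannot be told apart here, something the earlier pair could not show. With azepan-1-yl in place of (piperidin-1-yl)methyl, the result is a 2.4-fold higher number from compound 1 to compound 3 (0.39 log units; beyond the scatter), so compound 1 stands apart from compound 3 as well as from compound 2, whichever of the two rings is present. Nothing measured here explains these results.

The compounds shown leave open how much of the separation of compound 1 belongs to the ring and how much to the added methyl link, which piperidin-1-yl at this same carbon would help to divide. Also open, on these data alone, is how a morpholin-4-yl ring or an open-chain dimethylamino group would compare at this place.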